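Tyrphostin-type acrylonitriles on SMA cells: notes

The compounds below may be only part of what the source reports. "The series", "measured", "known", "first", "only" and "open" are said of these compounds alone.

Measured compounds and values:
- `N#C/C(=C\c1c[nH]c2ccccc12)C(=O)c1c[nH]c2ccccc12` compound 1, 15000 nM
- `COc1ccc(CNC(=O)/C(C#N)=C/c2ccc[nH]2)cc1` compound 2, > 50000 nM
- `N#C/C(=C\c1ccco1)C(=O)NCc1ccc(Cl)c(Cl)c1` compound 3, 38000 nM

In a functional assay on SMA cells (Homo sapiens) for inhibition, read by MTT assay, with a stated time of 72 h (a higher number here means a weaker inhibitor of growth, a lower number a stronger inhibitor of growth), compound 1 gives 15000 nM and compound 3 gives 38000 nM. Compound 2 returns only a limit, > 50000 nM, so its true value is not known. Compound 2 sits at the limit of > 50000 nM in this assay, at which 1 of the 3 values shown sits, the weak end of everything measured here.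

Compound 4, `COc1ccc(CNC(=O)/C(C#N)=C/c2ccc(Cl)cc2)cc1`, differs from compound 2 by 4-chlorophenyl in place of 1H-pyrrol-2-yl on a double-bonded chain carbon bound to a double-bonded chain carbon. For the measured compounds named here, no measured pair isolates this change, so no step can be read off. The expectation is a small step from compound 2 to compound 4 of an at least 1.2-fold lower number from compound 2 to compound 4 (0.09 log units; that floor lies within the scatter), in the direction of stronger growth inhibition, though the limit on compound 2 makes its size uncertain. Compound 4 is estimated at 40000 nM, within 15000 nM to 100000 nM.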

Compound 4, concentration for 50% growth inhibition: 17000 nM
Estimate against measurement, compound 4: 2.4-fold (0.37 log units) above; low and high end bracket the measured number.
By their numbers in this assay, from the lowest: compounds 1 and 4 (each within the scatter of the next); then compound 3. At a limit, above all of these: compound 2.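

In this assay, 4-chlorophenyl in place of 1H-pyrrol-2-yl on a double-bonded chain carbon bound to a double-bonded chain carbon gives an at least 2.9-fold lower number from compound 2 to compound 4 (0.46 log units; beyond the scatter). For the compounds shown here, this is the first step that isolates one change, and it shows that the group at this place alone can move growth inhibition beyond the scatter. Its full size cannot be read because compound 2 stands at a limit: the limit of > 50000 nM in this assay, at which 1 of the 4 values shown sits.

The compounds shown do not separate the chlorine from the change of ring, which a plain phenyl at this place would address. Going by these compounds, how an amine or a carboxylic acid on that ring would read also remains open.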